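Fluoro on the phenyl and the amine ring of a shared core

A few compounds are considered here, and "the series" means these few. Any claim that something is new, unique, unknown or untested is made for them only; others in the source may bear on it.

Measured so far:
compound 1 `COc1cc2c(Oc3ccc(NC(=O)c4nn(-c5ccccc5)c(=O)c5ccccc45)cc3F)ccnc2cc1OCCCN1CCCC1` — 480 nM
compound 2 `COc1cc2c(Oc3ccc(NC(=O)c4nn(-c5ccccc5F)c(=O)c5ccccc45)cc3F)ccnc2cc1OCCCN1CCCC1` — 230 nM
compound 3 `COc1cc2c(Oc3ccc(NC(=O)c4nn(-c5ccccc5)c(=O)c5ccccc45)cc3F)ccnc2cc1OCCCN1CCC(C)CC1` — 550 nM

All values come from a functional assay on NCI-H460 cells (Homo sapiens) for cytotoxicity, read by MTT assay, with a stated time of 72 h; on this read-out lower numbers stand for stronger inhibition and higher numbers for weaker inhibition. Compound 1 and compound 2 differ by fluoro in place of hydrogen on an aromatic carbon; this gave a 2.1-fold lower number from compound 1 to compound 2 (0.32 log units; beyond the scatter). Compound 1 and compound 3 differ in their cores by 4-methylpiperidin-1-yl in place of pyrrolidin-1-yl on a saturated chain carbon, three bonds along the chain from an oxygen on an aromatic ring, and that step, a 1.1-fold higher number from compound 1 to compound 3 (0.06 log units; within the scatter), stays within the scatter, so compound 1 and compound 3 read as the same. The pair of compound 2 and compound 3 carries two differences at once and only the two values are shown.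

Compound 4 `COc1cc2c(Oc3ccc(NC(=O)c4nn(-c5ccc(F)cc5)c(=O)c5ccccc45)cc3F)ccnc2cc1OCCCN1CCC(C)CC1` is not yet measured. It differs from compound 3 by fluoro in place of hydrogen on an aromatic carbon. This is the same kind of change as from compound 1 to compound 2, but the fluorine enters para rather than ortho to the large group, so the earlier step is a guide, not a copy. For compound 4 the step of a 1.4-fold lower number from compound 3 to compound 4 (0.14 log units; within the scatter) is expected in this assay, smaller than the measured one, resting on a 2.1-fold lower number from compound 1 to compound 2 (0.32 log units; beyond the scatter) and on the changed place. Compound 4 is estimated at 400 nM, between 230 nM and 700 nM.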

Compound 4, half-maximal inhibitory concentration: 110 nM
The estimate for compound 4 lay 3.6-fold (0.56 log units) above the measured number; the measured number lies below the stated range.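

In this assay, fluoro in place of hydrogen on the phenyl gives a lower number on both cores, and the new step is a 5.0-fold lower number from compound 3 to compound 4 (0.70 log units; beyond the scatter). Set beside the earlier step, it does not read as a different size: the same change on two cores in this assay, a 2.1-fold lower number (0.32 log units; beyond the scatter) from compound 1 to compound 2 and a 5.0-fold lower number (0.70 log units; beyond the scatter) from compound 3 to compound 4, 2.4-fold (0.38 log units) apart, within the scatter of two such steps. This supports carrying the change from the core of compound 1 to the core of compound 3, at least in direction, but two pairs do not fix a size for it, and they do not separate the effect of the amine ring from that of the fluoro's place, which is para to a large group in compound 4 and elsewhere on the phenyl in compound 2.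

Still open, going by these compounds, is how the 4-fluorophenyl group reads with pyrrolidin-1-yl on the chain, and how the fluoro placement of compound 2 reads with 4-methylpiperidin-1-yl. Also open, on these data alone, is whether chloro or methoxy on the phenyl, or morpholine as the amine ring, would follow the same course.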